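This account rests on a few compounds, and the source may have more. Where it says the series, first, only, none or still open, it means among the compounds named here.

In a functional assay on Hs-578T cells (Homo sapiens) for inhibition, read by sulforhodamine B assay, with a stated time of 48 h, tested at 10 uM (a lower number here means less inhibition, a higher number more inhibition at the concentration tested (going by the name of the read-out)), compound 1 `c1ccc2c(-c3cn4ccnc4c(-c4ccc5ncn(C6CCCCC6)c5c4)n3)cccc2c1` gives 3.62% and compound 2 `c1ccc(Cn2cnc3ccc(-c4nc(-c5cccc6ccccc56)cn5ccnc45)cc32)cc1` gives 5.98%. The two differ by benzyl in place of cyclohexyl on an aromatic nitrogen, and the step of a number 2.4 percentage points higher from compound 1 to compound 2 (within the scatter) is small. Compound 3 `c1cn2cc(-c3ccc4c(c3)ncn4C3CCCCC3)nc(-c3ccc4ncn(C5CCCCC5)c4c3)c2n1` gives 23.6% in this assay; the difference between the core of compound 3 and the core of compound 1 is not broken down here. Compound 4 `c1ccc(Cn2cnc3ccc(-c4nc(-c5ccc6c(c5)ncn6C5CCCCC5)cn5ccnc45)cc32)cc1` has not yet been tested in this assay; it differs from compound 3 by benzyl in place of cyclohexyl on an aromatic nitrogen, the same change as between compound 1 and compound 2. Because compound 1 to compound 2 gave only a number 2.4 percentage points higher from compound 1 to compound 2 (within the scatter), the step from compound 3 to compound 4 is expected to be a number 0.4 percentage points higher from compound 3 to compound 4 (within the scatter). Compound 4 is therefore estimated at 24% in this assay, expected to lie between 10% and 40%.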

Compound 4, a percentage reported as inhibition, at one concentration (the size of the read-out at that concentration, not a potency): 99.6%
Estimate against measurement, compound 4: 75.6 percentage points below, and the stated range ends below it.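

On the core of compound 3, benzyl in place of cyclohexyl on an aromatic nitrogen gives a number 76 percentage points higher from compound 3 to compound 4 (beyond the scatter) in this assay. The size of the step does not carry over from one core to the other: the same change on two cores in this assay, a number 2.4 percentage points higher (within the scatter) from compound 1 to compound 2 and a number 76 percentage points higher (beyond the scatter) from compound 3 to compound 4, 73.6 percentage points apart, beyond the scatter of two such steps. For these two pairs, the outcome of the change therefore depends on the core that carries it, but two pairs give no rule for any further core and do not show which feature of the core is responsible.

As far as these compounds go, what a longer alkyl chain or an amine on that nitrogen would give on the core of compound 3 remains open. Also open, from the compounds shown here alone, is how compound 4 behaves at other concentrations or in other cell lines.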